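Fused-ring substituent change: fluoro to trifluoromethyl

The source may report more compounds than this note shows. Statements on the series, on what has been measured and on what is new or still open speak of the compounds shown alone.

Compound 1 `FC(F)(F)c1ccc(-c2ccc(Cn3nnc4ccccc43)cc2)c(Cl)c1`: 0.5 mL/min/g
Compound 2 `Fc1cc(Cl)ccc1-c1ccc(Cn2nnc3c(F)cccc32)cn1`: 0.6 mL/min/g
Compound 3 `Fc1ccc2c(c1)nnn2Cc1ccc(-c2ccc(Cl)cc2F)nc1`: 0.5 mL/min/g

All three were run in an ADME assay on microsomes from liver (Rattus norvegicus, strain Wistar) for metabolic stability, tested at 2.5 uM; a lower number here means slower removal, a higher number faster removal of the compound. Compound 2 gives 0.6 mL/min/g, a number not separated from those of compound 1 or compound 3 beyond the usual scatter, so the three sit together. Compound 4 `Fc1cc(Cl)ccc1-c1ccc(Cn2nnc3c(C(F)(F)F)cccc32)cn1` is not yet measured. It differs from compound 2 in one place: trifluoromethyl in place of fluoro on an aromatic carbon. Within the data shown here, no step between measured compounds is available to calibrate this change, so the expectation rests on the narrow spread of the three measured numbers. For compound 4 the step of a 1.2-fold lower number from compound 2 to compound 4 (0.08 log units; within the scatter) is expected to stay within the scatter, with no clear direction. Compound 4 is estimated at 0.5 mL/min/g in this assay, with a range of 0.25 mL/min/g to 1.2 mL/min/g.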

Compound 4, intrinsic clearance in a liver preparation (reported as CLH), per the amount of preparation that the assay uses: 0.2 mL/min/g
Beside the measured number, compound 4's estimate is 2.5-fold (0.40 log units) above it; measured number outside the range, below it.
By their numbers in this assay, from the lowest: compound 4; then compounds 1, 3 and 2 (each within the scatter of the next).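

In this assay, trifluoromethyl in place of fluoro on this aromatic carbon gives a 3.0-fold lower number from compound 2 to compound 4 (0.48 log units; beyond the scatter), the only step shown and one that lies beyond the scatter. This position therefore registers a change, which the three earlier numbers, sitting together, could not show. No measurement available here accounts for the shift.

As far as these compounds go, whether a methyl group, a chloro group or an amine on the same carbon would move the number in the same direction stays open. So does whether trifluoromethyl would have a similar effect elsewhere on that ring.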